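This account rests on a few compounds, and the source may have more. Where it says the series, first, only, none or still open, it means among the compounds named here.

Going by the values given here, compound 1 `CCOC(=O)CC(C)CCCCCn1c(C)nc(-c2ccccc2)c1-c1ccccc1` is the only compound here with a measured number: in an assay on H4 cells for inhibition of Fatty-acid amide hydrolase 1 (Homo sapiens) (a higher number here means a weaker inhibitor, a lower number a stronger inhibitor), compound 1 gives 130 nM. Compound 2 `CNC(=O)NCCCCCCn1c(C)nc(-c2ccccc2)c1-c1ccccc1` reaches only a limit, > 10000 nM in this assay, so it sits at the limit of > 10000 nM in this assay, at which 1 of the 2 values shown sits. Among the compounds with values here, the one measured step, an at least 76-fold higher number from compound 1 to compound 2 (1.88 log units; beyond the scatter), is large. Compound 3 `Cc1nc(-c2ccccc2)c(-c2ccccc2)n1CCCCCC(C)NC(=O)Oc1ccccc1F` differs from compound 1 by ((2-fluorophenoxy)carbonyl)amino in place of (ethoxycarbonyl)methyl on a saturated chain carbon bound to two saturated chain carbons. Within the data shown here, that step alone bears on the new change, yet the group entering compound 3 is not the one entering compound 2, so only a moderate change is expected, a 3.3-fold lower number from compound 1 to compound 3 (0.51 log units; beyond the scatter). Compound 3 is therefore estimated at 40 nM, between 4 nM and 400 nM.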

Compound 3, half-maximal inhibitory concentration: 4.2 nM
For compound 3 the middle estimate is 9.5-fold (0.98 log units) above the measured one; low and high end bracket the measured number.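

Replacing the ester arm of compound 1 with an aromatic-ring group on this saturated chain carbon makes inhibition much stronger, not weaker: in this assay there is a 31-fold lower number from compound 1 to compound 3 (1.49 log units; beyond the scatter). Large gains are therefore possible at this position, whereas the earlier step showed only a large loss. Nothing measured here explains the gain.

On these data alone, the fluorine, the aromatic ring and the amino-carbonyl link all enter together, so their shares stay unknown. As far as these compounds go, whether ((phenoxy)carbonyl)amino without the fluorine, or a simple amine on this carbon, would behave alike remains open.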